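A few compounds are considered here, and "the series" means these few. Any claim that something is new, unique, unknown or untested is made for them only; others in the source may bear on it.

Working notes on the series. In a functional assay on HL-60 cells (Homo sapiens) for cytotoxicity, read by WST assay, with a stated time of 48 h (on this read-out higher numbers stand for an effect only at larger amounts of compound and lower numbers for an effect already at smaller amounts), compound 1 (`O=C1OC[C@H](Cc2ccccc2O)[C@H]1Cc1ccc(Cl)c(Cl)c1`) gives 33000 nM and compound 2 (`Cc1ccccc1C[C@H]1COC(=O)[C@@H]1Cc1ccc(Cl)c(Cl)c1`) gives 22000 nM and compound 3 (`O=C1OC[C@H](Cc2cccc(O)c2)[C@H]1Cc1ccc(Cl)c(Cl)c1`) gives 48000 nM on this measure. The place of the last value rests on two steps (a 1.5-fold higher number from compound 1 to compound 3 (0.16 log units; within the scatter)) and (a 2.2-fold higher number from compound 2 to compound 3 (0.34 log units; beyond the scatter)) and only the second of these exceeds the scatter. Compound 4 (`COc1cccc(C[C@H]2COC(=O)[C@@H]2Cc2ccc(Cl)c(Cl)c2)c1`) is reached from compound 3 by one change (methyl in place of hydrogen on an oxygen on an aromatic ring) with methyl in place of hydrogen on an oxygen on an aromatic ring. Among the compounds with values here, no measured step makes this exact change. The nearest is a different one, methyl in place of hydroxy on an aromatic carbon (a 1.5-fold lower number from compound 1 to compound 2 (0.18 log units; within the scatter)). A small expected move toward a lower number, within the scatter, follows (a 1.6-fold lower number from compound 3 to compound 4 (0.20 log units; within the scatter)). Compound 4 is estimated at 30000 nM (range 14000 nM to 65000 nM).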

Compound 4, half-maximal effective concentration: 34000 nM
Beside the measured number, compound 4's estimate is 1.1-fold (0.05 log units) below it; the range from low to high includes it.
By their numbers in this assay, from the lowest: compounds 2, 1, 4 and 3 (each within the scatter of the next, the first and the last beyond it).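

At this oxygen on an aromatic ring, going from hydroxy to methoxy gives a 1.4-fold lower number from compound 3 to compound 4 (0.15 log units; within the scatter), so in this assay the hydrogen on that oxygen can be replaced by methyl with no change beyond the scatter. The 3-methoxyphenyl compound also stays within the scatter of both 2-substituted compounds, with a 1.5-fold higher number from compound 2 to compound 4 (0.19 log units; within the scatter) and a 1.0-fold higher number from compound 1 to compound 4 (0.01 log units; within the scatter). On these data alone, whether a longer chain on that oxygen, or an amine in place of the methoxy, would move the number beyond the scatter remains open. Nothing at hand explains why these numbers stay so close.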